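A Swap on the Amide Carbonyl of Compound 3

A few compounds are considered here, and "the series" means these few. Any claim that something is new, unique, unknown or untested is made for them only; others in the source may bear on it.

Of the compounds shown here, three built on one shared core have been tested in an assay on HEK293 cells for displacement of a labelled ligand from NPC1-like intracellular cholesterol transporter 1 (Homo sapiens); a higher number here means a weaker inhibitor, a lower number a stronger inhibitor. Compound 1 `CC(C)(C)OC(=O)NCCCCCNC(=O)CN1CN(c2ccccc2)C2(CCN(C(=O)c3ccc(C(C)(C)C)cc3)CC2)C1=O` gives 13700 nM, compound 2 `CC1(C)CC(OC(=O)CN2CN(c3ccccc3)C3(CCN(C(=O)c4ccc(C(C)(C)C)cc4)CC3)C2=O)CC(C)(C)N1` gives 1300 nM, and compound 3 `CC(C)(C)c1ccc(C(=O)N2CCC3(CC2)C(=O)N(CC(=O)N2CCN(S(C)(=O)=O)CC2)CN3c2ccccc2)cc1` gives 19000 nM, the highest of the three numbers; its gap to compound 1 lies within the scatter, whereas the change a 15-fold higher number from compound 2 to compound 3 (1.16 log units; beyond the scatter) lies well beyond it. Compound 4 `CC(C)(C)OC(=O)NCCCNC(=O)CN1CN(c2ccccc2)C2(CCN(C(=O)c3ccc(C(C)(C)C)cc3)CC2)C1=O` differs from compound 3 by (3-((tert-butoxycarbonyl)amino)propyl)amino in place of 4-(methylsulfonyl)piperazin-1-yl on a carbonyl carbon. For the measured compounds named here, no measured step covers this exact swap, but compound 1 carries a close relative of the entering group and its number sits within the scatter of compound 3. Compound 4 is therefore expected to show a step of a 1.4-fold lower number from compound 3 to compound 4 (0.13 log units; within the scatter) that stays within the scatter. Compound 4 is estimated at 14000 nM, between 5000 nM and 40000 nM.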

Compound 4, half-maximal inhibitory concentration: 4500 nM
For compound 4 the middle estimate is 3.1-fold (0.49 log units) above the measured one, and the stated range ends above it.
By their numbers in this assay, from the lowest: compound 2; then compound 4; then compounds 1 and 3 (each within the scatter of the next).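

In this assay the ringless (3-((tert-butoxycarbonyl)amino)propyl)amino gives a 4.2-fold lower number from compound 3 to compound 4 (0.63 log units; beyond the scatter) against 4-(methylsulfonyl)piperazin-1-yl, so changing one amide for another on this carbonyl carbon can move the number beyond the scatter, although a 3.5-fold higher number from compound 2 to compound 4 (0.54 log units; beyond the scatter) leaves (2,2,6,6-tetramethylpiperidin-4-yl)oxy with the lower number. Chain length alone also moves the number: the shorter chain brings a 3.0-fold lower number from compound 1 to compound 4 (0.48 log units; beyond the scatter) with the end group unchanged. No measured evidence explains these steps.

Still open, going by these compounds, is whether an ethyl chain, or a free amine in place of the (tert-butoxycarbonyl)amino end, would lower the number further.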